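The compounds below may be only part of what the source reports. "The series", "measured", "known", "first", "only" and "open" are said of these compounds alone.

In a functional assay on MDA-MB-453 cells (Homo sapiens) for cytotoxicity, read by MTT assay, with a stated time of 72 h (a lower number here means a stronger inhibitor, a higher number a weaker inhibitor), compound 1 `CSCC[C@H](NC1=CC(=O)C=C(C[C@]2(C)[C@@H](C)CC[C@]3(C)C(C)=CCC[C@@H]23)C1=O)C(=O)O` gives 25600 nM, the lowest of three numbers and beyond the scatter of the other two. Compound 2 `CC(C)[C@@H](NC1=CC(=O)C=C(C(C)(C)C)C1=O)C(=O)O` gives 133000 nM and compound 3 `CC(C)C[C@H](NC1=CC(=O)C=C(C(C)(C)C)C1=O)C(=O)O` gives 84900 nM. Compound 4 `CC1=CCC[C@H]2[C@](C)(CC3=CC(=O)C=C(N[C@@H](C(=O)O)C(C)C)C3=O)[C@@H](C)CC[C@]12C` keeps the core of compound 1 and carries one change: 1-carboxy-2-methylpropyl in place of 1-carboxy-3-(methylsulfanyl)propyl on an amine nitrogen. Among the compounds with values here, no measured pair isolates this change. Within the data shown here, the only guide is that compound 2 at 133000 nM and compound 3 at 84900 nM lie within the scatter of each other, with different groups on that nitrogen. The estimated step of a 1.3-fold higher number from compound 1 to compound 4 (0.10 log units; within the scatter) is expected to stay within the scatter. For compound 4 the expected value is 32000 nM, with an estimated range of 13000 nM to 75000 nM.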

Compound 4, half-maximal inhibitory concentration: 8010 nM
For compound 4 the middle estimate is 4.0-fold (0.60 log units) above the measured one; the whole stated range lies above it.
By their numbers in this assay, from the lowest: compound 4; then compound 1; then compounds 3 and 2 (each within the scatter of the next).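

On the core of compound 1, the group on this amine nitrogen is not neutral in this assay: 1-carboxy-2-methylpropyl in place of 1-carboxy-3-(methylsulfanyl)propyl gives a 3.2-fold lower number from compound 1 to compound 4 (0.50 log units; beyond the scatter). Within the data shown here, this is the first step read on a single change at this position, and it leaves compound 4 with the lowest number of the four. Nothing measured here accounts for the step.

Going by these compounds, whether the step follows the loss of sulfur or the change in chain shape stays open. A 1-carboxypentyl group on the same nitrogen would separate the two.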